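From hydroxy to benzoyloxy on compound 3

This account rests on a few compounds, and the source may have more. Where it says the series, first, only, none or still open, it means among the compounds named here.

Compound 1 `CC1=CC[C@H]2[C@H](CC[C@]2(C)O)C(C)(C)[C@@H]1CC[C@H]1[C@]2(C)CC[C@H](OC(=O)c3ccncc3)C(C)(C)O[C@H]2CC[C@@]1(C)O` gives 18000 nM
Compound 2 `CC(=O)O[C@H]1CC[C@]2(C)[C@H](CC[C@@](C)(O)[C@H]2CC[C@@H]2C(C)=CC[C@@H]3C(C)=CC[C@@H]3C2(C)C)OC1(C)C` gives 39200 nM
Compound 3 `CC1=CC[C@H]2[C@H](CC[C@]2(C)O)C(C)(C)[C@@H]1CC[C@H]1[C@]2(C)CC/C(=N/O)C(C)(C)O[C@H]2CC[C@@]1(C)O` gives 42700 nM

In a functional assay on MDA-MB-231 cells (Homo sapiens) for antiproliferative activity, read by MTT assay, with a stated time of 72 h (a higher number here means a weaker inhibitor, a lower number a stronger inhibitor), compound 3 stands level with compound 2 within the scatter, and its number is higher than that of compound 1 by a margin beyond the scatter. Compound 4 `CC1=CC[C@H]2[C@H](CC[C@]2(C)O)C(C)(C)[C@@H]1CC[C@H]1[C@]2(C)CC/C(=N/OC(=O)c3ccccc3)C(C)(C)O[C@H]2CC[C@@]1(C)O` is the next structure to be tested. The change from compound 3 is benzoyl in place of hydrogen on an oxygen with benzoyl in place of hydrogen on an oxygen whose other neighbour is a double-bonded nitrogen.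

Within the data shown here, no measured pair isolates this change, so the expectation rests on weak evidence. Compound 1, an ester, gives 18000 nM and hints at a lower number for compound 4. Compound 2, also an ester, gives 39200 nM and goes against that hint. An expected step of a 1.6-fold lower number from compound 3 to compound 4 (0.22 log units; within the scatter) in this assay would therefore be modest, toward a lower number, and may well stay within the scatter. Compound 4 is estimated at 26000 nM with an expected range from 11000 nM to 55000 nM once it is measured.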

Compound 4, half-maximal inhibitory concentration: 27400 nM
Beside the measured number, compound 4's estimate is 1.1-fold (0.02 log units) below it; low and high end bracket the measured number.
By their numbers in this assay, from the lowest: compounds 1, 4, 2 and 3 (each within the scatter of the next, the first and the last beyond it).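

In this assay, benzoyl in place of hydrogen on an oxygen whose other neighbour is a double-bonded nitrogen gives a 1.6-fold lower number from compound 3 to compound 4 (0.19 log units; within the scatter) as the first step read at this position. The result shows that this oxygen can carry benzoyl instead of hydrogen, with its six-membered aromatic ring of carbon, while the number stays within the scatter of that of compound 3. Nothing at hand explains this outcome or ties it to any property of the benzoyl group.

As far as these compounds go, whether a longer alkyl chain, or a benzoyl ring bearing an amine or a carboxylic acid, would behave alike on this oxygen remains open. Compound 1 and compound 2 differ from compound 4 in more than one place, so they do not settle this.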